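Replacing the methylcyclohexyl group of compound 3

The source may hold more compounds than are shown below. What is called first, only, known or untested is meant among the compounds shown, and "the series" means these compounds.

Compound 1 `CCCCNC(=O)N1Cc2c(NC(=O)c3ccc(C)cc3)nn(C(=O)C3CC3)c2C1`: 17600 nM
Compound 2 `CC(C)C(=O)n1nc(NC(=O)c2ccccc2)c2c1CN(C(=O)c1ccccc1)C2`: 2020 nM
Compound 3 `CC(=O)n1nc(NC(=O)c2ccccc2)c2c1CN(C(=O)C1CCC(C)CC1)C2`: 12200 nM

All three compounds were tested in a functional assay on HCT-116 cells (Homo sapiens) for cytotoxicity, read by sulforhodamine B assay, with a stated time of 48 h; on this read-out higher numbers stand for weaker inhibition and lower numbers for stronger inhibition. There, compound 3 gives 12200 nM, which lies within the scatter of compound 1 at 17600 nM. Compound 2 gives 2020 nM, and the other two numbers both stand clearly higher.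

Compound 4 `CC(=O)n1nc(NC(=O)c2ccccc2)c2c1CN(C(=O)CCl)C2` is the next to be measured. It carries chloromethyl in place of 4-methylcyclohexyl on a carbonyl carbon of compound 3 (chloromethyl in place of 4-methylcyclohexyl on a carbonyl carbon). Among the measured compounds shown here, no pair of measured compounds differs in one place only, so the data give no direct guide to the size of this step. Compound 2, at 2020 nM, does show that a compound of this small set can reach a lower number than compound 3. On that thin basis, a moderate move toward stronger inhibition is expected, and the expected change is a 4.1-fold lower number from compound 3 to compound 4 (0.61 log units; beyond the scatter). For compound 4 the estimated value is 3000 nM, with an expected range of 700 nM to 12000 nM.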

Compound 4, half-maximal inhibitory concentration: 4100 nM
Estimate against measurement, compound 4: 1.4-fold (0.14 log units) below, within the range that was stated.
By their numbers in this assay, from the lowest: compound 2; then compound 4; then compounds 3 and 1 (each within the scatter of the next).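

In this assay, among the compounds shown here, the change gives the first step in this set that can be read in one place: a 3.0-fold lower number from compound 3 to compound 4 (0.47 log units; beyond the scatter). It shows that this carbonyl carbon does not need the 4-methylcyclohexyl group, with its seven heavy atoms and its ring, for a measurable effect on these cells, since chloromethyl, with two heavy atoms and no ring, gives a modestly lower number. No measurement shown accounts for this step, and this single exchange cannot separate losing the ring from gaining the chlorine.

Still open, as far as these compounds go, is how a plain methyl, a bromomethyl or an aminomethyl group on the same carbonyl carbon would compare with chloromethyl. Also open, from the compounds shown here alone, is whether this exchange would move the number the same way in the settings of compound 1 or compound 2.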